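Amide Substituent Changes and Thyrotropin Receptor Efficacy

The compounds below may be only part of what the source reports. "The series", "measured", "known", "first", "only" and "open" are said of these compounds alone.

Compound 1 `COc1cccc(-c2nc(SC)nc3sc(C(=O)NCc4ccccc4)c(N)c23)c1`: 3%
Compound 2 `COc1cccc(-c2nc(SC)nc3sc(C(=O)NCC#N)c(N)c23)c1`: 3.6%
Compound 3 `CSc1nc(-c2cccc(F)c2)c2c(N)c(C(=O)NC(C)(C)C)sc2n1`: 8.1%

In a functional assay on HEK293 cells for agonist activity at Thyrotropin receptor (Homo sapiens), read by cAMP accumulation (on this read-out higher numbers stand for larger maximal responses and lower numbers for smaller maximal responses), compound 2 gives 3.6%. Its number sits among those of compound 1 and compound 3, with compound 1 the nearer and compound 3 the further, and both gaps lie within the scatter. Compound 4 `COc1cccc(-c2nc(SC)nc3sc(C(=O)NNC(=O)OC(C)(C)C)c(N)c23)c1` differs from compound 2 by (tert-butoxycarbonyl)amino in place of cyanomethyl on an amide-type nitrogen. Going by the values given here, the only measured step touching the amide-type nitrogen is a number 0.6 percentage points higher from compound 1 to compound 2 (within the scatter), which lay within the scatter. Among the compounds with values here, no measured step covers the entering group itself, so the expectation rests on that one step alone. Compound 4 is expected to move by a number 1.4 percentage points higher from compound 2 to compound 4 (within the scatter). The estimate for compound 4 is 5%, within 0% to 15%.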

Compound 4, largest response reached (reported as efficacy), in percent of the reference or control that the assay uses: 1.9%
Beside the measured number, compound 4's estimate is 3.1 percentage points above it, and the stated range covers the measured number.
By their numbers in this assay, from the lowest: compounds 4, 1, 2 and 3 (each within the scatter of the next).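

In this assay, (tert-butoxycarbonyl)amino on the amide-type nitrogen gives a number 1.7 percentage points lower from compound 2 to compound 4 (within the scatter) and a number 1.1 percentage points lower from compound 1 to compound 4 (within the scatter). This position therefore takes a larger group, with a hydrogen-bond donor and no triple bond, without any step beyond the scatter from cyanomethyl or benzyl. No evidence on the cause of this result is available. Going by these compounds, it remains open whether an amine, a carboxylic acid or a longer chain on this nitrogen would give a step beyond the scatter. Compound 3 differs from these compounds in more than one place and cannot settle this.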